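Swapping the dienyl chain for a fluorophenyl on the shared core

The source may hold more compounds than are shown below. What is called first, only, known or untested is meant among the compounds shown, and "the series" means these compounds.

Compound 1 `C=C1CC[C@@H]2[C@](C)(CO)[C@H](O)CC[C@@]2(C)[C@@H]1/C=C/C1=C/C(=C/CCC)OC1=O` and compound 2 `C=C1CC[C@@H]2[C@](C)(CO)[C@H](O)CC[C@@]2(C)[C@@H]1/C=C/C1=C/C(=C/C=C(/C)CCC=C(C)C)OC1=O` share a core and differ in the chain on the lactone side. In an assay on isolated protein for inhibition of Maltase-glucoamylase (Homo sapiens), tested at 100 uM (on this read-out higher numbers stand for more inhibition at the one concentration tested (going by the name of the read-out) and lower numbers for less inhibition), compound 1 gives 43.5%, while compound 2 is reported as "not active" (no number reported), so no number places compound 2 on the scale. Compound 3 `C=C1CC[C@@H]2[C@](C)(CO)[C@H](O)CC[C@@]2(C)[C@@H]1/C=C/C1=C/C(=C/c2ccc(F)cc2)OC1=O` carries 4-fluorophenyl in place of 2,6-dimethylhepta-1,5-dien-1-yl on a double-bonded chain carbon bound to a double-bonded ring carbon. With no step shown between measured compounds, a gain beyond the scatter is expected in this assay, since compound 2 lacks a figure and compound 1 with its shorter chain gives 43.5%. Compound 3 is expected to give about 30%, in the range 5% to 55%.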

Compound 3, a percentage reported as inhibition, at one concentration (the size of the read-out at that concentration, not a potency): "not active" (no number reported)
For compound 3 the study gives words and no number, and the estimate cannot be compared.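

In this assay, for the compounds shown here, compound 2 reads "not active" (no number reported) and compound 3 reads "not active" (no number reported) so no step between them can be read. The compounds shown leave open how the 4-fluorophenyl and 2,6-dimethylhepta-1,5-dien-1-yl chains compare in inhibition. No evidence bears on this result.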